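Methoxy added to a thiol-bearing aminoquinazoline core

A few compounds are considered here, and "the series" means these few. Any claim that something is new, unique, unknown or untested is made for them only; others in the source may bear on it.

Compound 1 `COc1ccc(CNc2nc([Se]C)nc3ccccc23)cc1`: > 100000 nM in a functional assay on HTB-54 cells (Homo sapiens) for cytotoxicity, read by MTT assay, with a stated time of 72 h; on this read-out lower numbers stand for stronger inhibition of growth and higher numbers for weaker inhibition of growth
Compound 2 `Sc1nc(NCc2ccccc2)c2ccccc2n1`: > 100000 nM in this assay
Compound 3 `CSc1nc(NCc2ccccc2)c2ccccc2n1`: 82300 nM in this assay

Compound 2 stands at the limit of this assay, where its reading of > 100000 nM is a limit rather than a number, matching (the limit of > 100000 nM in this assay, at which 2 of the 3 values shown sit). Compound 4 `COc1ccc(CNc2nc(S)nc3ccccc23)cc1` differs from compound 2 by methoxy in place of hydrogen on an aromatic carbon. Going by the values given here, the only measured step, an at least 1.2-fold lower number from compound 2 to compound 3 (0.08 log units; that floor lies within the scatter), concerns the sulfur substituent and not the benzyl ring, so it offers little guidance here. Compound 1, which carries the same methoxy group, gives a limit of > 100000 nM. Compound 4 is therefore expected to stay at or near that limit, with an expected step that the limit leaves unreadable from compound 2 to compound 4 meaning no change beyond the scatter. The estimate for compound 4 is 150000 nM, ranging from 70000 nM to 400000 nM.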

Compound 4, concentration for total growth inhibition: 45500 nM
Estimate against measurement, compound 4: 3.3-fold (0.52 log units) above; the whole stated range lies above it.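

In this assay, methoxy on the six-membered aromatic ring, para to a large group, brings the thiol compounds off the limit, with an at least 2.1-fold lower number from compound 2 to compound 4 (0.34 log units; beyond the scatter). With that methoxy kept, one sulfur atom in place of the carbon and selenium group also matters, with an at least 2.1-fold lower number from compound 1 to compound 4 (0.34 log units; beyond the scatter). Both steps are floors rather than sizes because one end of each sits at a limit: the limit of > 100000 nM in this assay, at which 2 of the 4 values shown sit.

The compounds shown leave open whether an amine or ethoxy at that ring place would give a similar step. They also leave open how methoxy would act on compound 3, which carries methyl on the sulfur.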